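The source may hold more compounds than are shown below. What is called first, only, known or untested is meant among the compounds shown, and "the series" means these compounds.

Measured compounds in an in vitro assay on HEK-tsA201 cells for antagonist activity at Neuronal acetylcholine receptor; alpha4/beta2 (Homo sapiens), read by fluorescence and calcium flux; a lower number here means a stronger inhibitor, a higher number a weaker inhibitor:

Compound 1 `CCOc1ccc(C(=O)Nc2cc(C)cc(C)n2)cc1` gives 17100 nM.
Compound 2 `C=CCOc1ccc(C(=O)Nc2cccc(Cl)n2)cc1` gives only a limit of the assay, > 100000 nM.
Compound 3 `CCCNc1cccc(NC(=O)c2ccc(OCCC)cc2)n1` gives 15400 nM.

Compound 3 holds the lowest of the two numbers read out in this assay, with compound 1 as its nearest neighbour; that gap lies within the scatter of repeated measurements, so no order between compound 3 and compound 1 is claimed. The value of compound 2 is a limit and not a number, as noted in the limit of > 100000 nM in this assay, at which 1 of the 3 values shown sits, and it is not compared further. For the measured compounds named here, no step between two measured compounds that differ in a single place is available in this set, so the measured values give no direct guide to the size of any change.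

Compound 4 `CCCOc1ccc(C(=O)Nc2cccc(Nc3ccc(Cl)cc3)n2)cc1` is the next member to be measured in this assay. It differs from compound 3 in one place: 4-chlorophenyl in place of propyl on a nitrogen on an aromatic ring, which read one bond further out is propylamino to (4-chlorophenyl)amino. Going by the values given here, with no measured step of this kind to lean on, the expectation is a modest shift at best, and the estimated step from compound 3 to compound 4 is a 1.5-fold lower number from compound 3 to compound 4 (0.19 log units; within the scatter). Compound 4 is expected to give about 10000 nM in this assay, in a range from 2000 nM to 60000 nM.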

Compound 4, half-maximal inhibitory concentration: > 100000 nM
Compound 4: a limit, no number (the forecaster's own chance of this, stated with the estimate: 20%); middle value at least 10-fold (1.00 log units) away from the limit.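

In this assay compound 4 gives > 100000 nM, a limit of the assay and not a number. With 4-chlorophenyl in place of propyl on a nitrogen on an aromatic ring, the series gains its first readable single-place change, an at least 6.4-fold higher number from compound 3 to compound 4 (0.81 log units; beyond the scatter), which shows that activity at this position depends on the group carried by that nitrogen and that propyl cannot be exchanged for 4-chlorophenyl without a loss beyond the scatter. The step is only a lower bound on the size of the change, and the limit now accounts for a larger share of the series: the limit of > 100000 nM in this assay, at which 2 of the 4 values shown sit.

The compounds shown do not reveal the full size of the loss, nor do they separate the contribution of the six-membered aromatic ring from that of the chlorine or from the larger number of heavy atoms in the entering group. Plain phenyl, cyclohexyl, or a longer chain such as butyl on the same nitrogen would bear on these questions, as would a smaller group such as ethyl or methyl in showing how far the position extends in the other direction.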